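A Triazole Aryl Swap on a Cytotoxicity-Silent Core

A few compounds are considered here, and "the series" means these few. Any claim that something is new, unique, unknown or untested is made for them only; others in the source may bear on it.

compound 1 `C=C1C[C@]23C[C@@]1(O)CC[C@H]2c1ccc(O)c(C)c1[C@@H]3Cn1cc(-c2ccccn2)nn1` — > 20000 nM
compound 2 `Cc1c(O)ccc2c1[C@H](Cn1cc(-c3ccc(Cl)cc3)nn1)[C@@]13CC(=O)[C@@](C)(CC[C@@H]21)C3` — > 20000 nM
compound 3 `C=C1C[C@]23C[C@@]1(O)CC[C@H]2c1ccc(OS(=O)(=O)c2ccc(C)cc2)c(C)c1[C@@H]3Cn1cc(-c2ccc(OC)cc2)nn1` — > 20000 nM

In a functional assay on HL-60 cells (Homo sapiens) for cytotoxicity, read by MTT assay, with a stated time of 4 days (a lower number here means a stronger inhibitor, a higher number a weaker inhibitor), compound 1 gives > 20000 nM, a limit of the assay rather than a number. Compound 2 likewise gives > 20000 nM, again a limit. Compound 3 gives > 20000 nM, also a limit. Among the measured compounds shown here, compound 1 therefore stands nowhere distinct among the values shown, because of the limit of > 20000 nM in this assay, at which 3 of the 3 values shown sit; every compound measured so far sits at the same limit.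

Compound 4 `C=C1C[C@]23C[C@@]1(O)CC[C@H]2c1ccc(O)c(C)c1[C@@H]3Cn1cc(-c2ccc(C(F)(F)F)cc2)nn1` has not yet been measured. It differs from compound 1 by 4-(trifluoromethyl)phenyl in place of pyridin-2-yl on an aromatic carbon. For the measured compounds named here, no measured pair differs in one place, so no step of known size can be drawn on. With all three measured compounds at the limit, the step that the limit leaves unreadable from compound 1 to compound 4 is expected to be none beyond the scatter, and most likely the assay will again report a limit. Compound 4 is accordingly estimated at 25000 nM in this assay, with a range of 8000 nM to 80000 nM.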

Compound 4, half-maximal inhibitory concentration: 8950 nM
Compound 4: middle estimate off by 2.8-fold (0.45 log units), on the high side, within the range that was stated.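

Putting 4-(trifluoromethyl)phenyl in place of pyridin-2-yl on this aromatic carbon gives an at least 2.2-fold lower number from compound 1 to compound 4 (0.34 log units; beyond the scatter) in this assay, so the group held here can move the read-out on the core of compound 1. Compound 4 is the only compound shown that carries a measured number instead of a limit, which shows that this core is not silent in every form. The full size of the step cannot be read because compound 1 sits at a limit: the limit of > 20000 nM in this assay, at which 3 of the 4 values shown sit.

On these data alone, the aromatic ring and its substituent change together in this one step, so it stays open whether the trifluoromethyl group or the loss of the ring nitrogen goes with the lower number. Also open, as far as these compounds go, is how a plain phenyl or a carboxylic acid would read at this position.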